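A few compounds are considered here, and "the series" means these few. Any claim that something is new, unique, unknown or untested is made for them only; others in the source may bear on it.

Measured so far:
compound 1, `Oc1cccc(-c2cc(-c3cccs3)cc(-c3ccccc3O)n2)c1`, > 50000 nM
compound 2, `Oc1cccc(-c2cc(-c3cccs3)cc(-c3cccc(O)c3)n2)c1`, 1690 nM
compound 3, `Oc1cccc(-c2cc(-c3ccccn3)cc(-c3ccccc3O)n2)c1`, 2020 nM

The read-out is a functional assay on HeLa cells (Homo sapiens) for cytotoxicity, read by CCK-8 assay; on this read-out higher numbers stand for weaker inhibition and lower numbers for stronger inhibition. For compound 1 the value is a limit of the assay, not a number: the limit of > 50000 nM in this assay, at which 1 of the 3 values shown sits. Two single changes lead away from it. The first, (3-hydroxyphenyl in place of 2-hydroxyphenyl on an aromatic carbon), gives an at least 29-fold lower number from compound 1 to compound 2 (1.47 log units; beyond the scatter). The second, (pyridin-2-yl in place of thiophen-2-yl on an aromatic carbon), gives an at least 24-fold lower number from compound 1 to compound 3 (1.39 log units; beyond the scatter). Compound 2 and compound 3 themselves sit within the usual scatter of each other, so no order between them is claimed.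

Compound 4, `Oc1cccc(-c2cc(-c3ccccn3)cc(-c3cccc(O)c3)n2)c1`, has not been measured. It differs from compound 3 by 3-hydroxyphenyl in place of 2-hydroxyphenyl on an aromatic carbon. For the measured compounds named here, this is the same kind of change as the one from compound 1 to compound 2, but not the same: in the earlier case the changed position was meta to a thiophen-2-yl group, here it is meta to a pyridin-2-yl group. The two cores differ by pyridin-2-yl in place of thiophen-2-yl on an aromatic carbon.

Going by these compounds, since the value of compound 1 is a limit of the assay, the true size of the earlier step is unknown. Compound 3 already stands at 2020 nM, well inside the measurable range. The earlier step, an at least 29-fold lower number from compound 1 to compound 2 (1.47 log units; beyond the scatter), is therefore taken only as an upper bound. The step from compound 3 to compound 4 is expected to be smaller than that, and is estimated as a 3.4-fold lower number from compound 3 to compound 4 (0.53 log units; beyond the scatter). Compound 4 is thus expected to give about 600 nM, with a plausible span from 150 nM to 3000 nM.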

Compound 4, half-maximal inhibitory concentration: 6500 nM
For compound 4 the middle estimate is 11-fold (1.03 log units) below the measured one, outside the stated range (above it).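

On the core bearing pyridin-2-yl in this assay, 3-hydroxyphenyl in place of 2-hydroxyphenyl gives a 3.2-fold higher number from compound 3 to compound 4 (0.51 log units; beyond the scatter), so the change does not carry over in direction or size from the core bearing thiophen-2-yl: the same change on two cores in this assay, an at least 29-fold lower number (1.47 log units; beyond the scatter) from compound 1 to compound 2 and a 3.2-fold higher number (0.51 log units; beyond the scatter) from compound 3 to compound 4, at least 95-fold (1.97 log units) apart, beyond the scatter of two such steps

The second change behaves in the same way, as pyridin-2-yl in place of thiophen-2-yl gives a 3.8-fold higher number from compound 2 to compound 4 (0.59 log units; beyond the scatter) when both flanking rings are 3-hydroxyphenyl, and this too differs from its earlier counterpart: the same change on two cores in this assay, an at least 24-fold lower number (1.39 log units; beyond the scatter) from compound 1 to compound 3 and a 3.8-fold higher number (0.59 log units; beyond the scatter) from compound 2 to compound 4, at least 95-fold (1.97 log units) apart, beyond the scatter of two such steps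

The value of compound 1 is a limit of the assay, so the true size of both gaps stays unknown, and the four compounds show only that the two changes do not act independently here, not why they fail to: the limit of > 50000 nM in this assay, at which 1 of the 4 values shown sits.

Going by these compounds, it remains open whether the same reversal would appear with a third group, such as phenyl or furan-2-yl, in the place held by pyridin-2-yl and thiophen-2-yl. On these data alone, it is equally open whether a methoxy group or an amine in place of the hydroxyl on these rings would follow the same course.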